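Alpha-methyl on the linker of a thiophene aryloxyacetamide

A few compounds are considered here, and "the series" means these few. Any claim that something is new, unique, unknown or untested is made for them only; others in the source may bear on it.

Compound 1 `CCN(Cc1cccs1)C(=O)COc1ccc(C)cc1`: 8 nM
Compound 2 `CCc1ccc(OCC(=O)N(CC)Cc2cccs2)cc1`: 67 nM
Compound 3 `CCN(Cc1ccco1)C(=O)COc1ccc(C)cc1`: 489 nM

In an assay on HEK293 cells for agonist activity at transient receptor potential cation channel subfamily M member 8 (Homo sapiens), read by fluorescence and calcium flux, with a stated time of 15 min (on this read-out higher numbers stand for an effect only at larger amounts of compound and lower numbers for an effect already at smaller amounts), compound 1 gives the lowest number of the three; the nearest, compound 2, lies an 8.4-fold higher number from compound 1 to compound 2 (0.92 log units; beyond the scatter) away, and compound 3 lies furthest, a 61-fold higher number from compound 1 to compound 3 (1.79 log units; beyond the scatter).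

Compound 4 `CCN(Cc1cccs1)C(=O)C(C)Oc1ccc(C)cc1` differs from compound 1 by methyl in place of hydrogen on a saturated chain carbon bound to a carbonyl carbon and an oxygen on an aromatic ring. For the measured compounds named here, no measured step alters this part of the shared core. The two steps seen, an 8.4-fold higher number from compound 1 to compound 2 (0.92 log units; beyond the scatter) and a 61-fold higher number from compound 1 to compound 3 (1.79 log units; beyond the scatter), both moved away from compound 1 and beyond the scatter, so small changes elsewhere on this core have not been free. A step of similar direction but of uncertain size is expected for compound 4 in this assay, estimated at a 3.1-fold higher number from compound 1 to compound 4 (0.49 log units; beyond the scatter).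

Compound 4 is therefore expected to give about 25 nM, within 6 nM to 150 nM.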

Compound 4, half-maximal effective concentration: 889 nM
Compound 4: middle estimate off by 36-fold (1.55 log units), on the low side, and the stated range ends below it.
By their numbers in this assay, from the lowest: compound 1; then compound 2; then compounds 3 and 4 (each within the scatter of the next).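

At this saturated chain carbon, bound to a carbonyl carbon and an oxygen on an aromatic ring, one added methyl is enough for a large step in this assay (a 110-fold higher number from compound 1 to compound 4 (2.05 log units; beyond the scatter)). The same exchange of methyl for hydrogen on a saturated chain carbon bound to an aromatic carbon gave a smaller step (an 8.4-fold higher number from compound 1 to compound 2 (0.92 log units; beyond the scatter)), so the size of the step depends on where the methyl sits. Nothing available gives a reason for this. From the compounds shown here alone, whether a fluorine atom, a hydroxyl group or an ethyl chain at this carbon would give a step of similar size remains open.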